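Meta-substituent swap in a bis-amide cyclobutane series

This account rests on a few compounds, and the source may have more. Where it says the series, first, only, none or still open, it means among the compounds named here.

Compound 1 `Cc1cccc(NC(=O)C2(C(=O)Nc3ccc(Nc4ncc5cc(C(=O)N(C)C)n(C6CCCC6)c5n4)cc3)CC2)c1`: 45.7%
Compound 2 `CN(C)C(=O)c1cc2cnc(Nc3ccc(NC(=O)C4(C(=O)Nc5cccc(F)c5)CC4)cc3)nc2n1C1CCCC1`: -3.2%
Compound 3 `CN(C)C(=O)c1cc2cnc(Nc3ccc(NC(=O)C4(C(=O)Nc5ccccc5F)CC4)cc3)nc2n1C1CCCC1`: 85.2%

In a functional assay on T47D cells (Homo sapiens) for inhibition, read by CCK-8 assay, with a stated time of 72 h, tested at 1 uM (on this read-out higher numbers stand for more inhibition of growth at the one concentration tested and lower numbers for less inhibition of growth), compound 1 stands second highest of the three, well clear of both neighbours: compound 3 sits above it a number 39.5 percentage points higher from compound 1 to compound 3 (beyond the scatter) and compound 2 below it a number 48.9 percentage points lower from compound 1 to compound 2 (beyond the scatter). Compound 4 `CN(C)C(=O)c1cc2cnc(Nc3ccc(NC(=O)C4(C(=O)Nc5cccc(Cl)c5)CC4)cc3)nc2n1C1CCCC1` is not yet measured; it differs from compound 1 by chloro in place of methyl on an aromatic carbon. Within the data shown here, the only measured step that touches the same spot is the fall from compound 1 to compound 2 a number 48.9 percentage points lower from compound 1 to compound 2 (beyond the scatter), so the single exchange at that position has been seen to lower the number sharply. The account therefore expects compound 4 to drop in this assay as well, with a step of about a number 23.7 percentage points lower from compound 1 to compound 4 (beyond the scatter), while the two fluoro compounds show how strongly the value depends on which position is changed. Compound 4 is thus estimated at 22%, within -8% to 52%.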

Compound 4, percent growth inhibition at one concentration: 39.3%
Compound 4: middle estimate off by 17.3 percentage points, on the low side; measured number inside the range.
By their numbers in this assay, from the lowest: compound 2; then compounds 4 and 1 (each within the scatter of the next); then compound 3.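

In this assay chloro in place of methyl gives a number 6.4 percentage points lower from compound 1 to compound 4 (within the scatter), so the sharp loss seen with fluoro at this carbon does not follow from every exchange there. The swap of fluoro for chloro at the same carbon gives a number 42.5 percentage points higher from compound 2 to compound 4 (beyond the scatter), leaving compound 2 alone among the three at this spot, while a number 45.9 percentage points lower from compound 3 to compound 4 (beyond the scatter) shows that neither chloro nor methyl here reaches the 2-fluorophenyl compound. Nothing shown accounts for this difference between fluoro and chloro.

From the compounds shown here alone, whether a methoxy group, a nitrile or a dimethylamino group at this carbon would stay with methyl and chloro or go with fluoro remains open.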